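A few compounds are considered here, and "the series" means these few. Any claim that something is new, unique, unknown or untested is made for them only; others in the source may bear on it.

Working notes on the series, all read in a functional assay on HepG2 cells (Homo sapiens) for inhibition, read by MTT assay, with a stated time of 24 h; a lower number here means a stronger inhibitor, a higher number a weaker inhibitor. The shared core of compound 1 `CC1(C)[C@H]2CC[C@]1(C)N(Cc1cn(-c3ccc(F)cc3)nn1)C(=O)C2` carries a different substituted phenyl on an aromatic nitrogen in each measured member. Compound 1 gives 90 nM, compound 2 `CC1(C)[C@H]2CC[C@]1(C)N(Cc1cn(-c3ccccc3Cl)nn1)C(=O)C2` gives 60 nM, and compound 3 `CC1(C)[C@H]2CC[C@]1(C)N(Cc1cn(-c3cccc(O)c3)nn1)C(=O)C2` gives 70 nM. The last value sits within the scatter of the other two, with steps of a 1.2-fold higher number from compound 2 to compound 3 (0.07 log units; within the scatter) and a 1.3-fold lower number from compound 1 to compound 3 (0.11 log units; within the scatter).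

Next in line is compound 4 `COc1cccc(-n2cc(CN3C(=O)C[C@@H]4CC[C@@]3(C)C4(C)C)nn2)c1`, which differs from compound 3 as follows: methyl in place of hydrogen on an oxygen on an aromatic ring. This is hydroxy to methoxy, giving 3-methoxyphenyl in place of 3-hydroxyphenyl. Among the measured compounds shown here, no measured pair isolates this exact change, so the evidence is indirect. The closest guides are the two steps that introduce the 3-hydroxyphenyl, given above, along with the remaining swap of a 1.5-fold lower number from compound 1 to compound 2 (0.18 log units; within the scatter). All three lie within the scatter, so among these three compounds, exchanging the phenyl substituent has not yet shifted the number measurably. For the measured compounds named here, the data hold no hydroxy and methoxy pair to test whether this holds for compound 4.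

No step beyond the scatter is therefore expected, and the expected step is a 1.1-fold higher number from compound 3 to compound 4 (0.03 log units; within the scatter). For compound 4 the estimated value is 75 nM, with an expected range of 35 nM to 170 nM.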

Compound 4, half-maximal inhibitory concentration: 70 nM
Beside the measured number, compound 4's estimate is 1.1-fold (0.03 log units) above it, within the range that was stated.
By their numbers in this assay, from the lowest: compounds 2, 3, 4 and 1 (each within the scatter of the next).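

In this assay, among the compounds shown here, the hydroxy to methoxy exchange gives no change at the digits printed from compound 3 to compound 4 (within the scatter), and this is the only pair here that changes the group on the oxygen while leaving the rest of the 3-hydroxyphenyl in place. The 3-methoxyphenyl also falls in the same band as the other two phenyl substituents, with a 1.2-fold higher number from compound 2 to compound 4 (0.07 log units; within the scatter) and a 1.3-fold lower number from compound 1 to compound 4 (0.11 log units; within the scatter), so among these four compounds a free hydroxy hydrogen is not required for a number at this level. No measurement in hand offers an explanation for this result.

Still open, going by these compounds, is whether a larger group on this oxygen, such as ethoxy or a longer alkoxy chain, or a group of another kind in its place, such as an amine or a carboxylic acid, would move the number beyond the scatter. All four compounds lie within the scatter of one another, so the series does not yet show how far the number responds to any substituent on this phenyl.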